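A few compounds are considered here, and "the series" means these few. Any claim that something is new, unique, unknown or untested is made for them only; others in the source may bear on it.

Compound 3 `O=C(NO)c1cccc(-c2cn([C@H]3C[C@@H](CO)N(CCCc4ccccc4)C3)nn2)c1` carries a 3-phenylpropyl group on the ring amine nitrogen. In an assay on Sf9 cells for inhibition of histone deacetylase 11 (Homo sapiens), read by fluorescence, tested at 0.5 uM (on this read-out lower numbers stand for less inhibition and higher numbers for more inhibition at the one concentration tested (going by the name of the read-out)), compound 3 gives < 10%, which is a limit of the assay and not a number. Compound 2 `O=C(NO)c1cccc(-c2cn([C@H]3C[C@H](CO)N(CCCc4ccccc4)C3)nn2)c1` has the same atoms and bonds and differs only in configuration as drawn. In this assay compound 2 gives < 10%, again a limit. The step that the two limits leave unreadable from compound 2 to compound 3 cannot be read as a size, because the limit of < 10% in this assay, at which 3 of the 3 values shown sit, and because of the fact that compounds 2 and 3 differ only in the configuration as drawn. Compound 1 `O=C(NO)c1cccc(-c2cn([C@@H]3C[C@@H](CO)N(Cc4ccccc4)C3)nn2)c1`, which carries a benzyl group in another drawn configuration, stands in the same place: in this assay compound 1 gives < 10%, also a limit. Within the data shown here, no pair among the three compounds yields a readable step.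

Compound 4 `O=C(NO)c1cccc(-c2cn([C@H]3C[C@@H](CO)N(Cc4ccccc4)C3)nn2)c1` is to be measured in this assay. Relative to compound 3 the change is phenyl in place of phenethyl on a saturated chain carbon bound to an amine nitrogen in a ring. Among the measured compounds shown here, no measured step bears on this change: the only step at hand, from compound 2 to compound 3, is unreadable, and the benzyl compound 1 sits at the same limit as compound 3. The expectation for compound 4 is therefore no step beyond the scatter, a step that the limit leaves unreadable from compound 3 to compound 4, with the value again at the limit. Compound 4 is expected to give 5% in this assay, within 0% to 15%.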

Compound 4, a percentage reported as inhibition, at one concentration (the size of the read-out at that concentration, not a potency): < 10%
Compound 4 gave a limit, no number; the forecaster's own chance of this, stated with the estimate: 85%; the middle value lies beyond the limit too.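

In this assay compound 4 gives < 10%, a limit of the assay and not a number. The steps linking compound 4 with compound 3 and with compound 1 cannot be read, because of this: the limit of < 10% in this assay, at which 4 of the 4 values shown sit.

The compounds shown leave open whether the change from 3-phenylpropyl to benzyl or the drawn configuration affects inhibition in this assay at all.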